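From pyridin-4-yl to 3-hydroxyphenyl on a shared core

The source may hold more compounds than are shown below. What is called first, only, known or untested is meant among the compounds shown, and "the series" means these compounds.

Among the compounds with values here, in a functional assay on HL-60 cells (Homo sapiens) for cytotoxicity, read by ELISA, with a stated time of 2 days (on this read-out higher numbers stand for weaker inhibition and lower numbers for stronger inhibition), compound 1 (`Oc1cccc(-c2cc(-c3ccccc3)cc(-c3ccccc3)n2)c1`) gives 11500 nM, and compound 2 (`Oc1cccc(-c2cc(-c3ccccc3)cc(-c3ccncc3)n2)c1`) gives 23900 nM, the higher of the two numbers so far. Compound 3 (`Oc1cccc(-c2cc(-c3ccccc3)cc(-c3cccc(O)c3)n2)c1`) differs from compound 2 by a single change: 3-hydroxyphenyl in place of pyridin-4-yl on an aromatic carbon. In words, this is 3-hydroxyphenyl in place of pyridin-4-yl on an aromatic carbon. Within the data shown here, only one measured step bears on this carbon: a 2.1-fold higher number from compound 1 to compound 2 (0.32 log units; beyond the scatter), with pyridin-4-yl in place of phenyl. Among the measured compounds shown here, no measured compound yet carries 3-hydroxyphenyl, so the evidence is thin. The entering ring is of carbon only, like the phenyl of compound 1 at 11500 nM, so a return towards that number is expected. The expected change is modest and towards a lower number: a 2.0-fold lower number from compound 2 to compound 3 (0.30 log units; within the scatter). For compound 3 the estimated value is 12000 nM, with an expected range of 4000 nM to 35000 nM.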

Compound 3, half-maximal inhibitory concentration: 16400 nM
Beside the measured number, compound 3's estimate is 1.4-fold (0.14 log units) below it; measured number inside the range.
By their numbers in this assay, from the lowest: compounds 1, 3 and 2 (each within the scatter of the next, the first and the last beyond it).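

In this assay, the entering 3-hydroxyphenyl gives a 1.5-fold lower number from compound 2 to compound 3 (0.16 log units; within the scatter), so this change at the carbon next to the ring nitrogen cannot be told apart from the usual scatter. Set against the phenyl, the added hydroxy gives a 1.4-fold higher number from compound 1 to compound 3 (0.15 log units; within the scatter), which also stays within the scatter, so compound 3 is separated from neither neighbour, although compound 1 and compound 2 are separated from each other. No measurement at hand explains these numbers.

From the compounds shown here alone, it remains open whether any group at this carbon can take the number clearly beyond this narrow band. An aminomethyl group or a carboxylic acid on the entering ring, or a small chain such as methoxy in place of the hydroxy, would test whether this carbon responds at all.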